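A few compounds are considered here, and "the series" means these few. Any claim that something is new, unique, unknown or untested is made for them only; others in the source may bear on it.

Compound 1 `COc1cccc(-c2cn(C(=O)NCCCCc3ccccc3)c(=O)o2)c1` gives 341 nM in an assay on isolated protein for inhibition of acid ceramidase (Homo sapiens), read by LC-MS, with a stated time of 1 h; a higher number here means a weaker inhibitor, a lower number a stronger inhibitor.
Compound 2 `O=C(NCCCCc1ccccc1)n1cc(-c2ccncc2)oc1=O` gives 18 nM in this assay.

Compound 2 holds the lower of the two numbers in this assay. Among the measured compounds shown here, the single measured step, a 19-fold lower number from compound 1 to compound 2 (1.28 log units; beyond the scatter), shows that exchanging the aryl ring at this position can move the number a great deal. Compound 3 `O=C(NCCCCc1ccccc1)n1cc(-c2cscn2)oc1=O` carries the change (1,3-thiazol-4-yl in place of pyridin-4-yl on an aromatic carbon). For the measured compounds named here, no measured step covers this exact swap, so the direction is uncertain; a moderate shift from compound 2, a 2.2-fold higher number from compound 2 to compound 3 (0.35 log units; beyond the scatter), is expected. Compound 3 is estimated at 40 nM, with a likely range from 10 nM to 200 nM.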

Compound 3, half-maximal inhibitory concentration: 44 nM
For compound 3 the middle estimate is 1.1-fold (0.04 log units) below the measured one; the range from low to high includes it.
By their numbers in this assay, from the lowest: compound 2; then compound 3; then compound 1.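

In this assay the swap to 1,3-thiazol-4-yl gives a 2.4-fold higher number from compound 2 to compound 3 (0.39 log units; beyond the scatter) and so costs far less than the 3-methoxyphenyl ring does, which shows that compound 2 is not alone in reaching a low number at this position. A five-membered aromatic ring also serves here, as a 7.8-fold lower number from compound 1 to compound 3 (0.89 log units; beyond the scatter) shows, so both nitrogen-bearing rings lie below the 3-methoxyphenyl compound. Nothing available explains this order. Still open, as far as these compounds go, is how an unsubstituted phenyl ring or a pyridin-3-yl ring would compare at this position.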